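The source may report more compounds than this note shows. Statements on the series, on what has been measured and on what is new or still open speak of the compounds shown alone.

Compound 3 `CC(C)[C@H](NC(=O)CCN(C)C)c1cccc(F)c1N1CCN(C(=O)[C@@H]2CN(C(C)C)C[C@H]2c2ccc(C(F)(F)F)c(F)c2)CC1` stands second highest of the three numbers measured in an assay on HEK293 cells for displacement of a labelled ligand from Melanocortin receptor 4 (Homo sapiens); a higher number here means a weaker inhibitor, a lower number a stronger inhibitor: compound 3 gives 51 nM. Its nearest neighbour is compound 1 `CC(C)[C@H](NC(=O)CCN(C)C)c1cccc(F)c1N1CCN(C(=O)[C@@H]2CN(C(C)C)C[C@H]2c2cc(F)c(F)c(F)c2)CC1`, which in this assay gives 250 nM; furthest away lies compound 2 `CNCC(=O)N[C@H](c1cc(C)ccc1N1CCN(C(=O)[C@@H]2CN(C3CCOCC3)C[C@H]2c2ccc(Cl)cc2)CC1)C(C)C`, which gives 2.1 nM. For the measured compounds named here, only one measured step changes a single place, a 4.9-fold lower number from compound 1 to compound 3 (0.69 log units; beyond the scatter), and it swaps one fluorinated aromatic ring for another on a saturated ring carbon. Compound 4 `CC(C)[C@H](NC(=O)CCN(C)C)c1cccc(F)c1N1CCN(C(=O)[C@@H]2CN(C(C)C)C[C@H]2c2cc(F)cc(F)c2)CC1` carries 3,5-difluorophenyl in place of 3-fluoro-4-(trifluoromethyl)phenyl on a saturated ring carbon. This partly reverses the earlier move: the trifluoromethyl leaves, and the aromatic ring again bears only fluorines, though fewer than in compound 1. Going by the values given here, the one step that bears on this change, a 4.9-fold lower number from compound 1 to compound 3 (0.69 log units; beyond the scatter), was modest, so a step of similar size in the opposite direction is expected, which would leave compound 4 between compound 1 and compound 3 in this assay. Compound 4 is therefore estimated at 150 nM, with a range from 50 nM to 450 nM, an expected step of a 2.9-fold higher number from compound 3 to compound 4 (0.47 log units; beyond the scatter).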

Compound 4, inhibition constant: 7800 nM
Compound 4: the middle estimate sits 52-fold (1.72 log units) below what was measured; the measured number lies above the stated range.
By their numbers in this assay, from the lowest: compound 2; then compound 3; then compound 1; then compound 4.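

In this assay this position proves far more sensitive than the earlier change between two substituted rings suggested: 3,5-difluorophenyl in place of 3-fluoro-4-(trifluoromethyl)phenyl costs a great deal (a 150-fold higher number from compound 3 to compound 4 (2.18 log units; beyond the scatter)). A single atom accounts for a large loss, since hydrogen in place of one fluoro on the aromatic ring of 3,4,5-trifluorophenyl also gives a large step (a 31-fold higher number from compound 1 to compound 4 (1.49 log units; beyond the scatter)), and compound 4 is the one of these three close relatives with a hydrogen there. Nothing measured here explains this sensitivity.

Still open, going by these compounds, is whether a chlorine, a methoxy group or a nitrile in place of that hydrogen would restore the lower numbers on this core. Compound 2 differs in several places, so it cannot settle this.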